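The compounds below may be only part of what the source reports. "The series", "measured", "known", "first", "only" and "open" are said of these compounds alone.

Measured so far in a functional assay on FM3A cells (Mus musculus) for antiproliferative activity, read by cell counting, with a stated time of 2 days; a higher number here means a weaker inhibitor, a lower number a stronger inhibitor
compound 1 `COc1cc(C(=O)c2sc(Nc3ccc(F)cc3)nc2N)cc(OC)c1OC` gives 58 nM
compound 2 `COc1cc(C(=O)c2sc(Nc3ccc(C)cc3)nc2N)cc(OC)c1OC` gives 15 nM

Compound 2 holds the lower of the two numbers (15 nM), and its gap to compound 1 lies beyond the scatter. The next compound is compound 3 `COc1cc(C(=O)c2sc(Nc3ccc(Cl)cc3)nc2N)cc(OC)c1OC`, which has chloro in place of methyl on an aromatic carbon. Among the measured compounds shown here, only one measured step bears on this change. It is the modest swap of fluoro for methyl at the same place (a 3.9-fold lower number from compound 1 to compound 2 (0.59 log units; beyond the scatter)). For the measured compounds named here, compound 3 gives up the methyl of compound 2 and carries a halogen again, as compound 1 does, but no chloro compound has yet been measured and a single step sets no trend. A move back toward the number of compound 1 is therefore expected in this assay, smaller than the measured step. The estimated step is small and toward a higher number (a 1.9-fold higher number from compound 2 to compound 3 (0.27 log units; within the scatter)), not clearly beyond the scatter. For compound 3 the estimated value is 28 nM (expected range 11 nM to 70 nM).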

Compound 3, half-maximal inhibitory concentration: 420 nM
The estimate for compound 3 lay 15-fold (1.18 log units) below the measured number, and the stated range ends below it.
By their numbers in this assay, from the lowest: compound 2; then compound 1; then compound 3.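

In this assay, among the compounds shown here, chloro in place of methyl at this place, para to a large group, gives the largest step so far (a 28-fold higher number from compound 2 to compound 3 (1.45 log units; beyond the scatter)), well beyond what the earlier swap of fluoro for methyl showed (a 3.9-fold lower number from compound 1 to compound 2 (0.59 log units; beyond the scatter)). The two halogens also part clearly, since chloro in place of fluoro adds a further step of its own (a 7.2-fold higher number from compound 1 to compound 3 (0.86 log units; beyond the scatter)), so compound 1 and compound 3 cannot be read as one halogen class, and the order runs methyl, then fluoro, then chloro. Nothing measured in hand accounts for this order.

Still open, from the compounds shown here alone, is where bromo, methoxy, ethyl or plain hydrogen at this place would fall, and thus whether the low number of compound 2 belongs to methyl alone or extends to other carbon groups such as ethyl. Also open, going by these compounds, is whether the same order would hold on the core with the amine or the trimethoxyphenyl part changed, since all three compounds share both.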